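Swapping methoxy for fluorine on the hydrazone aryl group

A few compounds are considered here, and "the series" means these few. Any claim that something is new, unique, unknown or untested is made for them only; others in the source may bear on it.

Of the compounds shown here, two have been measured in an ADME assay on WI-38 cells (Homo sapiens) for cytotoxicity, read by MTT assay, with a stated time of 72 h; a lower number here means a stronger inhibitor, a higher number a weaker inhibitor. Compound 1 `CN(C)CCn1cnnc1-c1cc(Oc2ccc(NC(=O)N/N=C/c3cc(C(C)(C)C)cc(C(C)(C)C)c3O)cc2F)ccn1` gives 2350 nM. Compound 2 `COc1ccc(/C=N/NC(=O)Nc2ccc(Oc3ccnc(-c4nncn4CCN(C)C)c3)c(F)c2)c(OC)c1` gives 6630 nM, the highest of the two numbers; its nearest neighbour is compound 1, whose number is lower by a gap beyond the scatter. Compound 3 `CN(C)CCn1cnnc1-c1cc(Oc2ccc(NC(=O)N/N=C/c3ccc(F)cc3F)cc2F)ccn1` carries 2,4-difluorophenyl in place of 2,4-dimethoxyphenyl on a carbon with a double bond to nitrogen. Within the data shown here, no measured pair shows this change, so the step of a 1.3-fold lower number from compound 2 to compound 3 (0.12 log units; within the scatter) is expected to be small, with no clear direction beyond the scatter. Compound 3 is therefore expected to give 5000 nM, in the range from 1500 nM to 16000 nM.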

Compound 3, half-maximal inhibitory concentration: 5030 nM
Estimate against measurement, compound 3: 1.0-fold (0.00 log units) below; low and high end bracket the measured number.
By their numbers in this assay, from the lowest: compound 1; then compounds 3 and 2 (each within the scatter of the next).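

In this assay, among these compounds, putting 2,4-difluorophenyl in place of 2,4-dimethoxyphenyl on a carbon with a double bond to nitrogen gives a 1.3-fold lower number from compound 2 to compound 3 (0.12 log units; within the scatter) and so offers the first direct reading of this change. The hydrogen-bond acceptors of the methoxy groups leave with it, yet this pair shows no difference beyond the scatter. Nothing measured here explains this outcome.

The compounds shown leave open whether a different group at this position, such as a pyridine ring or a phenyl ring carrying an amine, would shift the number beyond the scatter. They also leave open whether this swap would behave the same way on another core.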